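This account rests on a few compounds, and the source may have more. Where it says the series, first, only, none or still open, it means among the compounds named here.

Measured so far in a physicochemical assay for solubility, in phosphate buffer, at pH 7.4; on this read-out higher numbers stand for higher solubility and lower numbers for lower solubility:

Compound 1 `OCC1CCN(c2nccnc2Oc2ccc(Nc3nc4ccccc4s3)cc2)CC1`: 6000 nM
Compound 2 `OC1CCN(c2nccnc2OC2CN(c3ccc4ccccc4n3)C2)CC1`: 99000 nM

Compound 2, at 99000 nM, holds the higher of the two values, while compound 1, at 6000 nM, lies lower by more than the usual scatter. For the measured compounds named here, with only two compounds, that is all the numbers can show.

The next compound, compound 3 `OCc1cccc(-c2nccnc2OC2CN(c3ccc4ccccc4n3)C2)c1`, has not yet been measured. It keeps the core of compound 2 but carries 3-(hydroxymethyl)phenyl in place of 4-hydroxypiperidin-1-yl on an aromatic carbon, next to the ring nitrogen: 3-(hydroxymethyl)phenyl in place of 4-hydroxypiperidin-1-yl on an aromatic carbon.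

Going by the values given here, no measured pair isolates this change, since compound 1 and compound 2 differ in more than one place, so any expectation remains loose. Among the compounds with values here, the only lower reference is compound 1 at 6000 nM. In this assay, a fall beyond the scatter is expected, of moderate size, and the estimate is a 5.0-fold lower number from compound 2 to compound 3 (0.69 log units; beyond the scatter). For compound 3 the estimated value is 20000 nM, with an expected range from 4000 nM to 80000 nM.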

Compound 3, solubility: 29000 nM
Compound 3: the middle estimate sits 1.5-fold (0.16 log units) below what was measured; the range from low to high includes it.
By their numbers in this assay, from the lowest: compound 1; then compound 3; then compound 2.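

For the compounds shown here, compound 3 gives the first comparison in this set that differs in one place: on an aromatic carbon of a six-membered aromatic ring with 2 nitrogen, next to the ring nitrogen, 3-(hydroxymethyl)phenyl in place of 4-hydroxypiperidin-1-yl gives in this assay a 3.4-fold lower number from compound 2 to compound 3 (0.53 log units; beyond the scatter) as a modest step. This position therefore responds to the exchange of a six-membered non-aromatic ring with 1 hetero atom for a six-membered aromatic ring of carbon only, even though both groups carry a hydroxy function. No measurement shown here offers an explanation for the step.

With only this one change read at this position, the compounds shown leave open whether the step follows the ring, the hydroxymethyl chain or the two together. On these data alone, how a plain phenyl, a 3-(aminomethyl)phenyl, a morpholin-4-yl or a piperidin-1-yl without the hydroxy group would stand in this assay against compound 2 also remains open, as does whether the same exchange would give a similar step on another core.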